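From 4-Methylpiperazin-1-yl to Piperazin-1-yl: One Small Change

The compounds below may be only part of what the source reports. "The series", "measured", "known", "first", "only" and "open" are said of these compounds alone.

For the measured compounds named here, in an ADME assay on NIH3T3 cells (Mus musculus) for cytotoxicity (a lower number here means that less compound is tolerated, a higher number that more compound is tolerated), compound 1 `CN1CCN(CC#Cc2cc3ncnc(Nc4ccc(OCc5cccc(F)c5)c(Cl)c4)c3s2)CC1` gives 4.8 uM, the only actual number among the three compounds measured so far. Compound 2 `CC(C)(C)CC#Cc1cc2ncnc(Nc3ccc(OCc4cccc(F)c4)c(Cl)c3)c2s1` reaches only a limit of the assay, > 50 uM. Compound 3 `CN(C)CC#Cc1cc2ncnc(Nc3ccc(OCc4cccc(F)c4)c(Cl)c3)c2s1` reaches the same limit, > 50 uM.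

Compound 4 `Fc1cccc(COc2ccc(Nc3ncnc4cc(C#CCN5CCNCC5)sc34)cc2Cl)c1` has not yet been measured. Its structure differs from that of compound 1 by hydrogen in place of methyl on an amine nitrogen in a ring.

Two measured steps offer indirect guidance. Tert-butyl in place of 4-methylpiperazin-1-yl gives an at least 10-fold higher number from compound 1 to compound 2 (1.01 log units; beyond the scatter), and dimethylamino in its place gives an at least 10-fold higher number from compound 1 to compound 3 (1.01 log units; beyond the scatter). Both steps are large, but each replaces the whole 4-methylpiperazin-1-yl group, whereas compound 4 keeps the ring and loses only the methyl. Going by the values given here, no step of that size is therefore expected in this assay, and compound 1 at 4.8 uM remains the closest guide. The expected step is small and towards a higher number, a 1.5-fold higher number from compound 1 to compound 4 (0.16 log units; within the scatter). The estimate for compound 4 is 7 uM, with an expected range from 2.5 uM to 25 uM.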

Compound 4, half-maximal toxic concentration: > 50 uM
Compound 4 was reported as a limit; the forecaster's own chance of this, stated with the estimate: 12%; at least 7.1-fold (0.85 log units) between middle value and limit.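

In this assay, hydrogen in place of methyl on the amine nitrogen in the ring gives an at least 10-fold higher number from compound 1 to compound 4 (1.01 log units; beyond the scatter). The earlier steps shown here each replaced the whole 4-methylpiperazin-1-yl group, whereas this one shows that the ring can stay and that losing a single carbon at this position is enough for a large step. Compound 4 is reported only as a limit of the assay, and its steps to compound 2 and compound 3 cannot be read: the limit of > 50 uM in this assay, at which 3 of the 4 values shown sit.

From the compounds shown here alone, how far past that limit compound 4 really lies remains open. An ethyl or an acetyl group on the same ring nitrogen would show whether the lower number of compound 1 belongs to methyl alone or to any group placed there.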